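The source may report more compounds than this note shows. Statements on the series, on what has been measured and on what is new or still open speak of the compounds shown alone.

Working notes on the series as read in a functional assay on B16-F10 cells (Mus musculus) for antiproliferative activity, read by ELISA and MTT assay, with a stated time of 48 h; on this read-out lower numbers stand for stronger inhibition and higher numbers for weaker inhibition. Compound 1 `O=C(/C=C/c1ccccc1)NS(=O)(=O)c1ccc(F)cc1` gives 2.1 ug/mL in this assay. Within the data shown here, compound 2 `Cc1ccc(S(=O)(=O)NC(=O)/C=C/c2ccc(Cl)cc2)cc1` gives 4.6 ug/mL in this assay, the highest of the two numbers so far; its nearest neighbour is compound 1, whose number lies lower by a margin beyond the usual scatter. Among the measured compounds shown here, compounds 1 and 2 differ from each other in more than one place, so no single-point step between measured compounds is available to lean on.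

Compound 3 `O=C(/C=C/c1ccc(Cl)cc1)NS(=O)(=O)c1ccc(F)cc1` is next to be measured. Relative to compound 2 the change is fluoro in place of methyl on an aromatic carbon. The same exchange, cut one bond further out, reads 4-methylphenyl to 4-fluorophenyl. Compound 3 thus carries the fluoro of compound 1 together with the chloro of compound 2, and its number is expected to sit between the two values measured. The step of a 1.5-fold lower number from compound 2 to compound 3 (0.19 log units; within the scatter) is expected to be a small decrease, close to the edge of the scatter. Compound 3 is therefore estimated at 3 ug/mL, with a range from 1.5 ug/mL to 6 ug/mL.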

Compound 3, half-maximal inhibitory concentration: 2 ug/mL
Compound 3: the middle estimate sits 1.5-fold (0.18 log units) above what was measured; the range from low to high includes it.
By their numbers in this assay, from the lowest: compounds 3 and 1 (each within the scatter of the next); then compound 2.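

Among these compounds, with the chloro held constant, the change from 4-methylphenyl to 4-fluorophenyl gives a 2.3-fold lower number from compound 2 to compound 3 (0.36 log units; beyond the scatter) in this assay, the first single-point step to lie beyond the scatter, though it is modest in size. The other single-point comparison gives a 1.1-fold lower number from compound 1 to compound 3 (0.02 log units; within the scatter): with the fluoro held constant, chloro in place of hydrogen leaves the two compounds within the scatter of each other, so among these three compounds only the fluoro-for-methyl exchange produces a readable difference. No measurement in hand accounts for either step.

The compounds shown leave open whether the fluoro-for-methyl step keeps its size without the chloro, and whether chloro in place of hydrogen would stay within the scatter with the methyl in place of the fluoro. They also leave open how this assay would read other groups on the same aromatic carbon, such as an amine, a nitrile or a carboxylic acid, since fluoro and methyl are the only two compared there.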